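Carbamate variation on the bis-trimethoxybenzoyl piperazine series

The source may report more compounds than this note shows. Statements on the series, on what has been measured and on what is new or still open speak of the compounds shown alone.

Two members of the series have been measured. Compound 1 `CCCCCC(=O)OCC1CN(C(=O)c2cc(OC)c(OC)c(OC)c2)CCN1C(=O)c1cc(OC)c(OC)c(OC)c1` carries a pentyl ester; in a functional assay (Oryctolagus cuniculus) for inhibition of platelet-activating factor receptor (Cavia porcellus) (a higher number here means a weaker inhibitor, a lower number a stronger inhibitor), compound 1 gives 290 nM. Compound 2 `CCC(C)(C)NC(=O)OCC1CN(C(=O)c2cc(OC)c(OC)c(OC)c2)CCN1C(=O)c1cc(OC)c(OC)c(OC)c1` carries a (1,1-dimethylpropyl)carbamate in the same place; in this assay compound 2 gives 320 nM. On these two numbers compound 2 sits alongside compound 1, and the step of a 1.1-fold higher number from compound 1 to compound 2 (0.04 log units; within the scatter) does not separate the two: the exchange of ester for carbamate left the read-out essentially unchanged.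

Compound 3 `CCCN(CCC)C(=O)OCC1CN(C(=O)c2cc(OC)c(OC)c(OC)c2)CCN1C(=O)c1cc(OC)c(OC)c(OC)c1` is not yet measured. Relative to compound 2 the change is dipropylamino in place of (1,1-dimethylpropyl)amino on a carbonyl carbon. The only step that bears on it, the step from the pentyl ester to the branched carbamate a 1.1-fold higher number from compound 1 to compound 2 (0.04 log units; within the scatter), was within the scatter, so the carbonyl-bearing side chain has so far shown no leverage on this assay. From the compounds shown here alone, the loss of the hydrogen-bond donor is untested and is the main uncertainty.

Compound 3 is therefore expected to give 350 nM in this assay, with a range of 150 nM to 900 nM. The step of a 1.1-fold higher number from compound 2 to compound 3 (0.04 log units; within the scatter) is expected to stay within the scatter.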

Compound 3, half-maximal inhibitory concentration: 380 nM
Compound 3: the middle estimate sits 1.1-fold (0.04 log units) below what was measured, within the range that was stated.
By their numbers in this assay, from the lowest: compounds 1, 2 and 3 (each within the scatter of the next).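

The change to dipropylamino takes away the hydrogen-bond donor that (1,1-dimethylpropyl)amino carries, yet in this assay the result is a 1.2-fold higher number from compound 2 to compound 3 (0.07 log units; within the scatter), so in this pair the loss of that donor on a carbonyl carbon does not separate the two compounds. Against the pentyl ester the comparison gives a 1.3-fold higher number from compound 1 to compound 3 (0.12 log units; within the scatter), which means that a pentyl group, a branched carbamate and a carbamate with two propyl chains all stand within the scatter of one another, and the side chain has still shown no leverage on this read-out. No supporting measurement bears on this result.

The three compounds shown span only saturated carbon side chains of similar size, leaving open whether a carboxylic acid, a primary amine, a phenyl ring or a much longer chain such as decyl on this carbonyl carbon would move the number beyond the scatter. Also open, from the compounds shown here alone, is whether this tolerance holds when one of the trimethoxybenzoyl groups is replaced, for instance by an unsubstituted benzoyl group, since both stay the same throughout.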